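Swapping the Amine on the Chain of Compound 3

This account rests on a few compounds, and the source may have more. Where it says the series, first, only, none or still open, it means among the compounds named here.

In a functional assay on MCF7 cells (Homo sapiens) for antiproliferative activity (a lower number here means a stronger inhibitor, a higher number a weaker inhibitor), compound 3 `CC(C)=CCc1cc(C(=O)Nc2cc3ccc(OCCCN(C)C(C)C)c(C)c3oc2=O)ccc1O` gives 1050 nM, level within the scatter with compound 1 `CC(C)=CCc1cc(C(=O)Nc2cc3ccc(OCC4CCCNC4)c(C)c3oc2=O)ccc1O` at 790 nM. Compound 2 `CCCN(CCC)CCCOc1ccc2cc(NC(=O)c3ccc(O)c(CC=C(C)C)c3)c(=O)oc2c1C` is reported only as a limit, > 50000 nM. Compound 4 `CC(C)=CCc1cc(C(=O)Nc2cc3ccc(OCCCNC(C)(C)C)c(C)c3oc2=O)ccc1O` carries (tert-butyl)amino in place of isopropyl(methyl)amino on a saturated chain carbon, three bonds along the chain from an oxygen on an aromatic ring. Two large steps, an at least 63-fold higher number from compound 1 to compound 2 (1.80 log units; beyond the scatter) and an at least 47-fold lower number from compound 2 to compound 3 (1.67 log units; beyond the scatter), show that this end of the chain can matter. Yet a 1.3-fold higher number from compound 1 to compound 3 (0.12 log units; within the scatter) stayed within the scatter, and the same atoms are merely rejoined here. Only a small change is therefore expected, a 1.2-fold higher number from compound 3 to compound 4 (0.09 log units; within the scatter). For compound 4 the estimated value is 1300 nM, with an expected range of 400 nM to 6000 nM.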

Compound 4, half-maximal inhibitory concentration: 950 nM
For compound 4 the middle estimate is 1.4-fold (0.14 log units) above the measured one; the range from low to high includes it.
By their numbers in this assay, from the lowest: compounds 1, 4 and 3 (each within the scatter of the next). At a limit, above all of these: compound 2.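

Gaining a hydrogen-bond donor on the amine at the same atom count leaves this assay flat (a 1.1-fold lower number from compound 3 to compound 4 (0.04 log units; within the scatter)). The 2-((tert-butyl)amino)ethyl chain also stays level with the piperidin-3-yl group (a 1.2-fold higher number from compound 1 to compound 4 (0.08 log units; within the scatter)), so three different amines at this place now sit together. Only dipropylamino stands apart (an at least 52-fold lower number from compound 2 to compound 4 (1.72 log units; beyond the scatter)), and that step rests on a limit for compound 2: the limit of > 50000 nM in this assay, at which 1 of the 4 values shown sits.

On these data alone, what a primary amine, a morpholine ring or a longer chain would give at this place stays open.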